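Swapping the aryl group on the hydrazone carbon in a cytotoxicity series

The source may report more compounds than this note shows. Statements on the series, on what has been measured and on what is new or still open speak of the compounds shown alone.

Measured so far:
compound 1, `COc1ccccc1-c1nnc(-c2ccc(C(=O)N/N=C/c3ccc(F)cc3)cc2)o1`, 427000 nM
compound 2, `COc1ccccc1-c1nnc(-c2ccc(C(=O)N/N=C/c3ccccn3)cc2)o1`, 67000 nM

Both compounds were tested in an ADME assay on THP-1 cells (Homo sapiens) for cytotoxicity; on this read-out lower numbers stand for stronger inhibition and higher numbers for weaker inhibition. Compound 2 gives the lowest of the two numbers in this assay; its nearest neighbour, compound 1, stands at 427000 nM, and the change between them is a 6.4-fold lower number from compound 1 to compound 2 (0.80 log units; beyond the scatter).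

Compound 3, `COc1ccccc1-c1nnc(-c2ccc(C(=O)N/N=C/c3cccc(O)c3O)cc2)o1`, is not yet measured. It differs from compound 2 in one place:

2,3-dihydroxyphenyl in place of pyridin-2-yl on a carbon with a double bond to nitrogen

Among the compounds with values here, only one measured step bears on this change. It altered the same position, the group on a carbon with a double bond to nitrogen, and it was modest in size. With a single step to go on, and that step pointing to lower numbers when the group at that place was exchanged, compound 3 is expected to land near compound 2 or somewhat lower, with wide uncertainty. The estimated step from compound 2 to compound 3 is a 1.3-fold lower number from compound 2 to compound 3 (0.13 log units; within the scatter). Compound 3 is therefore estimated at 50000 nM, within a range of 15000 nM to 200000 nM.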

Compound 3, half-maximal inhibitory concentration: 102000 nM
The estimate for compound 3 lay 2.0-fold (0.31 log units) below the measured number; the measured number falls inside the stated range.
By their numbers in this assay, from the lowest: compounds 2 and 3 (each within the scatter of the next); then compound 1.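

In this assay, putting 2,3-dihydroxyphenyl in place of pyridin-2-yl on a carbon with a double bond to nitrogen gives a 1.5-fold higher number from compound 2 to compound 3 (0.18 log units; within the scatter), so two quite different groups read alike here, even though the entering group has 2 hydrogen-bond donors and the leaving group has none. Set against 4-fluorophenyl, the same group gives a 4.2-fold lower number from compound 1 to compound 3 (0.62 log units; beyond the scatter), which shows that a step to lower numbers at this place is not confined to pyridin-2-yl and leaves 4-fluorophenyl standing apart among the three groups. No measurement at hand accounts for this.

The compounds shown leave open how much either hydroxyl of the 2,3-dihydroxyphenyl group contributes alone, and how an unsubstituted phenyl, a morpholine or a carboxylic acid would read at this place. They also leave open whether these differences persist in other cell types.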